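Swapping chloro for fluoro on a fused aromatic ring

A few compounds are considered here, and "the series" means these few. Any claim that something is new, unique, unknown or untested is made for them only; others in the source may bear on it.

Measured compounds:
Compound 1 `CC1(C)CC(NC(=O)Nc2cccc(Cl)c2)c2cc(F)ccc2O1` gives 45000 nM in a functional assay on T98G cells (Homo sapiens) for inhibition, read by MTT assay, with a stated time of 72 h; on this read-out higher numbers stand for weaker inhibition and lower numbers for stronger inhibition.
Compound 2 `CC1(C)CC(NC(=O)Nc2cccc(Cl)c2)c2cc(Cl)ccc2O1` gives 25000 nM in this assay.
Compound 3 `CC1(C)CC(NC(=S)Nc2cccc([N+](=O)[O-])c2)c2cc(Cl)ccc2O1` gives 4000 nM in this assay.

Compound 3 and compound 2 differ in more than one place, and the difference between the two cores is not broken down here. What compound 3 and compound 2 show together is that compound 3 has the lowest number of the three measured.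

The change from compound 2 to compound 1 is fluoro in place of chloro on an aromatic carbon, and it produced a 1.8-fold higher number from compound 2 to compound 1 (0.26 log units; within the scatter). The same change, (fluoro in place of chloro on an aromatic carbon), leads from compound 3 to the still unmeasured compound 4 `CC1(C)CC(NC(=S)Nc2cccc([N+](=O)[O-])c2)c2cc(F)ccc2O1`. The place is the same word for word in both pairs, so this is the same change.

Resting on the step that compound 2 to compound 1 showed, the expected step in this assay is a 1.6-fold higher number from compound 3 to compound 4 (0.21 log units; within the scatter), set beside that earlier one. Compound 4 is therefore estimated at 6500 nM, between 2500 nM and 18000 nM.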

Compound 4, half-maximal inhibitory concentration: 9000 nM
Beside the measured number, compound 4's estimate is 1.4-fold (0.14 log units) below it, within the range that was stated.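

On the second core, fluoro in place of chloro gave a 2.3-fold higher number from compound 3 to compound 4 (0.35 log units; beyond the scatter) in this assay. Set beside the earlier step, the two sizes cannot be told apart: the same change on two cores in this assay, a 1.8-fold higher number (0.26 log units; within the scatter) from compound 2 to compound 1 and a 2.3-fold higher number (0.35 log units; beyond the scatter) from compound 3 to compound 4, 1.3-fold (0.10 log units) apart, within the scatter of two such steps. The change therefore carried across these two cores with a similar size, but two pairs cannot show that it would do so on any other core in the series, and they do not explain why the number moves.

The compounds shown leave open what a bromo group, a methoxy group or a plain hydrogen would give at the same place. They also leave open how much of the gap between compound 2 and compound 3 comes from each place in which those two differ.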